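Purine nucleosides with varied benzylamine substituents: antiproliferative read-out

The source may hold more compounds than are shown below. What is called first, only, known or untested is meant among the compounds shown, and "the series" means these compounds.

Measured compounds:
- compound 1 `OC[C@H]1O[C@@H](n2cnc3c(NCc4ccccc4F)ncnc32)[C@H](O)[C@@H]1O`; in a functional assay on HOS cells (Homo sapiens) for antiproliferative activity, with a stated time of 72 h (a lower number here means a stronger inhibitor, a higher number a weaker inhibitor), compound 1 gives > 166000 nM, which is a limit of the assay and not a number.
- compound 2 `OC[C@H]1O[C@@H](n2cnc3c(NCc4ccc(F)cc4)ncnc32)[C@H](O)[C@@H]1O`; in this assay compound 2 gives 13200 nM.

Compound 2 holds the only number shown; the one further value is a limit. Going by the values given here, the single measured step, an at least 12-fold lower number from compound 1 to compound 2 (1.09 log units; beyond the scatter), rests on the limit of > 166000 nM in this assay, at which 1 of the 2 values shown sits, and is therefore only a lower bound on its size.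

Compound 3 `COc1ccccc1CNc1ncnc2c1ncn2[C@@H]1O[C@H](CO)[C@@H](O)[C@H]1O` is not yet measured. It differs from compound 2 as follows: 2-methoxyphenyl in place of 4-fluorophenyl on a saturated chain carbon bound to a nitrogen on an aromatic ring. Compound 1 carries 2-fluorophenyl at the same place and gave only a limit, so the measured step bears on this change in reverse sense. A step toward a higher number, beyond the scatter, is expected: a 4.5-fold higher number from compound 2 to compound 3 (0.66 log units; beyond the scatter). Compound 3 is estimated at 60000 nM, within 15000 nM to 170000 nM, with a real chance that only a limit is reported.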

Compound 3, half-maximal inhibitory concentration: > 166000 nM
Compound 3 was reported as a limit; the forecaster's own chance of this, stated with the estimate: 35%; at least 2.7-fold (0.44 log units) between middle value and limit.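

In this assay compound 3 gives > 166000 nM, which is a limit and not a number. The change from 4-fluorophenyl to 2-methoxyphenyl gives an at least 12-fold higher number from compound 2 to compound 3 (1.09 log units; beyond the scatter), so 2-fluorophenyl and 2-methoxyphenyl both end at the limit, and of the three compounds only 4-fluorophenyl gives a number. The size of this step is only a lower bound: the limit of > 166000 nM in this assay, at which 2 of the 3 values shown sit.

The step between compound 1 and compound 3 cannot be read, as both values are limits, so methoxy and fluoro cannot be ranked on this ring. As far as these compounds go, the step from compound 2 also changes the substituent and its place together, and it remains open what a methoxy at the place of the fluoro of compound 2, or an amine there, would give.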